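The compounds below may be only part of what the source reports. "The series", "measured", "known", "first", "only" and "open" are said of these compounds alone.

Working notes on the series. Compound 1 `CN1CCN(C(=O)CCCOc2cc(C(=O)N3CCCCc4sccc43)ccc2NC(=O)c2ccccc2-c2ccccc2)CC1` gives 1 nM in an assay on adrenal medulla for inhibition of Vasopressin V2 receptor (Rattus norvegicus), read by radioligand binding (on this read-out lower numbers stand for stronger inhibition and higher numbers for weaker inhibition), and stands lowest of the two numbers shown. Compound 2 `CN(C)C1CCN(C(=O)COc2cc(C(=O)N3CCCCc4sccc43)ccc2NC(=O)c2ccccc2-c2ccccc2)CC1` gives 4 nM in this assay. Compound 3 `CN1CCCN(CCCOc2cc(C(=O)N3CCCCc4sccc43)ccc2NC(=O)c2ccccc2-c2ccccc2)CC1` gives < 1 nM in this assay, which is a limit of the assay rather than a number. Compound 4 `CCN(CC)C1CCN(C(=O)CCCOc2cc(C(=O)N3CCCCc4sccc43)ccc2NC(=O)c2ccccc2-c2ccccc2)CC1` differs from compound 1 in that (4-(diethylamino)piperidin-1-yl in place of 4-methylpiperazin-1-yl on a carbonyl carbon). The step that bears on it is a 4.0-fold higher number from compound 1 to compound 2 (0.60 log units; beyond the scatter), where the chain was shortened as well; a number no higher from compound 1 to compound 3 (the limit leaves the size open) and an at least 4.0-fold lower number from compound 2 to compound 3 (0.60 log units; beyond the scatter) concern a different amine. Since the chain is kept here, a small step is expected, a 2.0-fold higher number from compound 1 to compound 4 (0.30 log units; within the scatter), weakening at most modestly. Compound 4 is estimated at 2 nM, from 0.7 nM to 6 nM.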

Compound 4, half-maximal inhibitory concentration: 6 nM
Beside the measured number, compound 4's estimate is 3.0-fold (0.48 log units) below it; the measured number falls inside the stated range.
By their numbers in this assay, from the lowest: compound 1; then compounds 2 and 4 (each within the scatter of the next).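

With the chain kept, the amine on the carbonyl carbon alone moves the number beyond the scatter, a 6.0-fold higher number from compound 1 to compound 4 (0.78 log units; beyond the scatter). This position therefore does not accept 4-(diethylamino)piperidin-1-yl in place of 4-methylpiperazin-1-yl without some loss, a point the earlier step with a shortened chain could not settle.

On these data alone, a 4-ethylpiperazin-1-yl on this carbonyl carbon would separate the effect of the ethyl groups from that of the ring, and its place here remains open. How far the low end of the series extends also stays open, since compound 3 gives a limit and not a number: the limit of < 1 nM in this assay, at which 1 of the 4 values shown sits.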